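The source may hold more compounds than are shown below. What is called first, only, known or untested is meant among the compounds shown, and "the series" means these compounds.

For the measured compounds named here, compound 1 `CCN(CC)CN1C(=O)C(=O)c2c(Cl)cccc21` gives 34100 nM in a functional assay on MCF7 cells (Homo sapiens) for cytotoxicity, read by sulforhodamine B assay, with a stated time of 48 h (on this read-out higher numbers stand for weaker inhibition of growth and lower numbers for stronger inhibition of growth), the highest of the three numbers measured so far. Compound 2 `Cc1ccc2nc(/N=C3\C(=O)N(CN(C)C)c4cccc(Cl)c43)sc2c1` gives 20700 nM and compound 3 `CCN(CC)CN1C(=O)C(=O)c2c(Br)cccc21` gives 20200 nM in this assay; both lie within the scatter of compound 1. Going by the values given here, the only single change measured so far, a 1.7-fold lower number from compound 1 to compound 3 (0.23 log units; within the scatter), stayed within the scatter. Compound 4 `O=C1C(=O)N(CN2CCCCC2)c2cccc(Cl)c21` differs from compound 1 by piperidin-1-yl in place of diethylamino on a saturated chain carbon bound to an amide-type nitrogen in a ring. Among the compounds with values here, no measured step touches this part of the molecule, so nothing among the measured compounds argues for a shift beyond the scatter. The step expected in this assay is therefore a 1.1-fold lower number from compound 1 to compound 4 (0.06 log units; within the scatter). Compound 4 is estimated at 30000 nM in this assay, with a range from 12000 nM to 75000 nM.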

Compound 4, concentration for 50% growth inhibition: 51200 nM
Compound 4: middle estimate off by 1.7-fold (0.23 log units), on the low side, and the stated range covers the measured number.
By their numbers in this assay, from the lowest: compounds 3, 2, 1 and 4 (each within the scatter of the next, the first and the last beyond it).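

In this assay, for the compounds shown here, the first change at this position, a 1.5-fold higher number from compound 1 to compound 4 (0.18 log units; within the scatter), swaps the open diethylamino for piperidin-1-yl, which brings in a six-membered non-aromatic ring. This position on a saturated chain carbon bound to an amide-type nitrogen in a ring therefore accepts this one ring with no shift that stands clear of the scatter. No measurement at hand gives a reason for this result.

Still open, going by these compounds, is whether a morpholine ring, with its added oxygen atom, or a longer chain between the ring nitrogen and the amine would move the number beyond the scatter. On these data alone, it is also open whether piperidin-1-yl behaves the same way on the bromo compound 3.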